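Chlorine Position on the Sulfur-Bound Benzyl Arm

A few compounds are considered here, and "the series" means these few. Any claim that something is new, unique, unknown or untested is made for them only; others in the source may bear on it.

Compound 1, `CC1=C(C(=O)Nc2ccc(F)cc2)C(c2ccc([N+](=O)[O-])cc2)N=C(SCc2cccc(Cl)c2)N1`: 21.1%
Compound 2, `CC1=C(C(=O)Nc2ccc(F)cc2)C(c2ccc([N+](=O)[O-])cc2)N=C(SCc2ccc(Cl)cc2)N1`: 39.7%
Compound 3, `CC1=C(C(=O)Nc2ccc(Br)cc2)C(c2ccc(Cl)cc2Cl)N=C(SCc2cccc(Cl)c2)N1`: 20.6%

Of the compounds shown here, three have been tested in a functional assay on the whole organism (artery, strain albino) with Rattus norvegicus as the target, with a stated time of 360 min, at a dose of 10 mg/kg by the oral route; on this read-out higher numbers stand for more inhibition at the one dose given (going by the name of the read-out) and lower numbers for less inhibition. Compound 1 and compound 2 differ in one place only: 4-chlorophenyl in place of 3-chlorophenyl on a saturated chain carbon bound to a sulfur. That single change produced the step of a number 18.6 percentage points higher from compound 1 to compound 2 (beyond the scatter). Compound 3 carries a different core; how its core differs from that of compound 1 is not broken down here, and the two numbers for compound 3 and compound 1 lie within the usual scatter of each other.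

Compound 4, `CC1=C(C(=O)Nc2ccc(Br)cc2)C(c2ccc(Cl)cc2Cl)N=C(SCc2ccc(Cl)cc2)N1`, is not yet measured. It differs from compound 3 by 4-chlorophenyl in place of 3-chlorophenyl on a saturated chain carbon bound to a sulfur, the same change that separates compound 1 from compound 2, at the same place. Because that change gave a number 18.6 percentage points higher from compound 1 to compound 2 (beyond the scatter) once already, the expected step is a number 17.4 percentage points higher from compound 3 to compound 4 (beyond the scatter). Compound 4 is therefore estimated at 38%, with a likely range from 22% to 55%. Among the measured compounds shown here, only one earlier example supports this, so the range is kept wide.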

Compound 4, a percentage reported as inhibition, in the whole organism at one dose (the size of the read-out at that dose, not a potency): 39.7%
Beside the measured number, compound 4's estimate is 1.7 percentage points below it, and the stated range covers the measured number.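

Changing 3-chlorobenzyl to 4-chlorobenzyl gave a number 19.1 percentage points higher from compound 3 to compound 4 (beyond the scatter) in this assay. The step seen earlier therefore appeared again at about the same size on a second core: the same change on two cores in this assay, a number 18.6 percentage points higher (beyond the scatter) from compound 1 to compound 2 and a number 19.1 percentage points higher (beyond the scatter) from compound 3 to compound 4, 0.5 percentage points apart, within the scatter of two such steps This shows that the change carried over between these two cores, but it does not show that it would carry over to other cores, and two pairs tested at a single dose cannot explain why the 4-chlorobenzyl compounds read higher.

The compounds shown leave open how a plain benzyl group, a longer chain or an amine would read in place of the chlorobenzyl arm. On these data alone, whether the step would hold at other doses or times also remains open.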